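TLR8 agonism: an aryl amide replaces a cyclobutyl amide

The source may hold more compounds than are shown below. What is called first, only, known or untested is meant among the compounds shown, and "the series" means these compounds.

Two compounds of the shared core have numbers in an assay on HEK293 cells for agonist activity at Toll-like receptor 8 (Homo sapiens), read by a luciferase reporter, with a stated time of 6 h; a higher number here means that more compound is needed for the effect, a lower number that less compound is needed. Compound 1 `CCCCNc1nc(N)nc2c1CN(S(C)(=O)=O)CC2` carries a methylsulfonyl on the ring amine nitrogen, and in this assay compound 1 gives 9.9 uM. Compound 2 `CCCCNc1nc(N)nc2c1CN(C(=O)C1CCC1)CC2` carries a cyclobutylcarbonyl in that position, and in this assay compound 2 gives 0.4 uM. The single step between them, a 25-fold lower number from compound 1 to compound 2 (1.39 log units; beyond the scatter), is the only one available, and it leaves compound 2 with the lowest of the two numbers shown.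

Compound 3 `CCCCNc1nc(N)nc2c1CN(C(=O)c1ccccn1)CC2` differs from compound 2 by pyridin-2-yl in place of cyclobutyl on a carbonyl carbon. Going by the values given here, the one measured step concerns an exchange of methylsulfonyl for an amide rather than an exchange of the group on the carbonyl carbon, so it bears on compound 3 only in that the amide is kept. Nothing in the data speaks to cyclobutyl against pyridin-2-yl on the carbonyl carbon, so no step beyond the scatter is expected in this assay. Compound 3 is therefore estimated to give 0.6 uM in this assay, within a range of 0.15 uM to 2.5 uM, which corresponds to an expected step of a 1.5-fold higher number from compound 2 to compound 3 (0.18 log units; within the scatter).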

Compound 3, minimum effective concentration: 2.9 uM
The estimate for compound 3 lay 4.8-fold (0.68 log units) below the measured number; the whole stated range lies below it.
By their numbers in this assay, from the lowest: compound 2; then compound 3; then compound 1.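

The group on the carbonyl carbon proves to matter in its own right: in this assay there is a 7.3-fold higher number from compound 2 to compound 3 (0.86 log units; beyond the scatter) when pyridin-2-yl takes the place of cyclobutyl, even though the amide is kept. So the earlier gain over the methylsulfonyl compound did not belong to the carbonyl alone, and this position responds to what the carbonyl carries. The amide keeps an advantage with either group, since there is still a 3.4-fold lower number from compound 1 to compound 3 (0.53 log units; beyond the scatter) and this is a smaller step than a 25-fold lower number from compound 1 to compound 2 (1.39 log units; beyond the scatter) for the cyclobutylcarbonyl. Nothing available gives a reason for the rise from the cyclobutyl to the pyridin-2-yl amide.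

The compounds shown leave open whether the higher number goes with the ring nitrogen of pyridin-2-yl or with the aromatic ring as such, a question that a phenyl on the same carbonyl carbon would separate. Also open, going by these compounds, is how a cyclopentyl or an open chain such as isopropyl would stand there against cyclobutyl, and so whether compound 2 marks a limit for this position.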